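A Methyl on the Imidazole of Compound 2

This account rests on a few compounds, and the source may have more. Where it says the series, first, only, none or still open, it means among the compounds named here.

Compound 1 `CS(=O)(=O)OC(c1ccccc1)c1cc2ccccc2o1` and compound 2 `c1ccc(C(c2cc3ccccc3o2)n2ccnc2)cc1` are both known only as limits. In a functional assay on HL-60 cells (Homo sapiens) for inhibition, read by MTT assay, with a stated time of 48 h (a higher number here means a weaker inhibitor, a lower number a stronger inhibitor), compound 1 gives > 40000 nM, a limit of the assay. In this assay compound 2 gives > 40000 nM, again a limit. The step that the two limits leave unreadable from compound 1 to compound 2 is therefore unreadable, and the limit of > 40000 nM in this assay, at which 2 of the 2 values shown sit, shows where both values sit. Compound 3 `Cc1nccn1C(c1ccccc1)c1cc2ccccc2o1` differs from compound 2 by methyl in place of hydrogen on an aromatic carbon. Going by the values given here, no measured step bears on this change, and compound 2 offers only a limit, so compound 3 is expected to sit near that limit too, the expected step being a step that the limit leaves unreadable from compound 2 to compound 3. Compound 3 is estimated at 60000 nM, between 10000 nM and 200000 nM.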

Compound 3, half-maximal inhibitory concentration: > 40000 nM
Compound 3 gave a limit, no number (the forecaster's own chance of this, stated with the estimate: 75%); the middle value does not contradict the limit.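

No step can be read among compound 1, compound 2 and compound 3, since each is known only as a limit: the limit of > 40000 nM in this assay, at which 3 of the 3 values shown sit. In this assay the compounds shown leave open how strongly any of the three inhibits, and whether the methyl of compound 3 changes that.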